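This account rests on a few compounds, and the source may have more. Where it says the series, first, only, none or still open, it means among the compounds named here.

Compound 1 `O=C1C=C(NCc2ccccc2)C(=O)c2c1nc1n2[C@H]2OC[C@@H](O)[C@H]2OC1` gives 2670 nM in a functional assay on MGC-803 cells (Homo sapiens) for inhibition, read by sulforhodamine B assay; a lower number here means a stronger inhibitor, a higher number a weaker inhibitor. Compound 2 `COc1ccccc1NC1=CC(=O)c2c(nc3n2[C@H]2OC[C@@H](O)[C@H]2OC3)C1=O` gives 1670 nM. Compound 3 `COc1ccc(NC2=CC(=O)c3c(nc4n3[C@H]3OC[C@@H](O)[C@H]3OC4)C2=O)cc1` gives 2150 nM.

Compound 1 has the highest of the three numbers, but compound 3 sits within the scatter of it and compound 2, the furthest away, also sits within the scatter, so these three values cannot be placed in an order.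

Compound 4 `O=C1C=C(Nc2ccc(C(F)(F)F)cc2)C(=O)c2c1nc1n2[C@H]2OC[C@@H](O)[C@H]2OC1` has not yet been measured. It differs from compound 1 in one place: 4-(trifluoromethyl)phenyl in place of benzyl on an amine nitrogen. Among the compounds with values here, the one step that bears on a change to the group on the amine nitrogen is a 1.3-fold higher number from compound 2 to compound 3 (0.11 log units; within the scatter), which is within the scatter, and the two aryl-bearing compounds 2 and 3 both give numbers within the scatter of the benzyl-bearing compound 1. Nothing here separates a benzyl from an aryl group on that nitrogen, and nothing addresses a trifluoromethyl group. Compound 4 is therefore expected to land near compound 1, with a step of a 1.3-fold lower number from compound 1 to compound 4 (0.10 log units; within the scatter) that is not expected to exceed the scatter. The estimate for compound 4 is 2100 nM, with a range from 700 nM to 6500 nM.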

Compound 4, half-maximal inhibitory concentration: 2820 nM
Beside the measured number, compound 4's estimate is 1.3-fold (0.13 log units) below it; low and high end bracket the measured number.
By their numbers in this assay, from the lowest: compounds 2, 3, 1 and 4 (each within the scatter of the next).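

In this assay, replacing benzyl with 4-(trifluoromethyl)phenyl on the amine nitrogen gives a 1.1-fold higher number from compound 1 to compound 4 (0.02 log units; within the scatter) and so stays within the scatter. This is the first step shown that goes directly from benzyl to a substituted phenyl group at this position, and the first to bring in a trifluoromethyl group; neither produces a readable change in this assay. No measurement is available that would explain this result.

Whether a different kind of group on this amine nitrogen, such as an amine, a carboxylic acid or a longer chain, would move the number beyond the scatter remains open, since every step shown so far stays within it. Going by these compounds, what changes to the shared core itself would do also remains open.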